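The source may report more compounds than this note shows. Statements on the series, on what has been measured and on what is new or still open speak of the compounds shown alone.

Compound 1 `COc1ncnc2c1c(-c1ccsc1)cn2[C@@H]1O[C@H](CO)[C@@H](O)[C@H]1O` is the reference point. In an ADME assay on BJ cells (Homo sapiens), read by MTT assay, with a stated time of 72 h (a higher number here means a weaker inhibitor, a lower number a stronger inhibitor), compound 1 gives 64300 nM, the lowest of the two numbers measured here. Compound 3 `Cc1ncnc2c1c(-c1ccsc1)cn2[C@@H]1O[C@H](CO)[C@@H](O)[C@H]1O`, which carries methyl in place of methoxy on an aromatic carbon, gives 96900 nM, and the step of a 1.5-fold higher number from compound 1 to compound 3 (0.18 log units; within the scatter) stays within the scatter. Compound 2 `CNc1ncnc2c1c(-c1ccsc1)cn2[C@@H]1O[C@H](CO)[C@@H](O)[C@H]1O`, with methylamino in place of methoxy on an aromatic carbon, reaches (the limit of > 100000 nM in this assay, at which 1 of the 3 values shown sits), so the value of compound 2, > 100000 nM, is a limit of the assay and not a number. The step of an at least 1.5-fold higher number from compound 1 to compound 2 (0.19 log units; that floor lies within the scatter) can therefore only be given as a floor. Compound 4 `C#Cc1cn([C@@H]2O[C@H](CO)[C@@H](O)[C@H]2O)c2ncnc(OC)c12` has not been measured. It differs from compound 1 by ethynyl in place of thiophen-3-yl on an aromatic carbon. Going by the values given here, none of the measured steps touches that position; all of them vary the group on the other aromatic carbon, and none moves the number beyond the scatter. Among the compounds with values here, no measured step thus bears directly on this change, and the step expected in this assay is a 1.1-fold higher number from compound 1 to compound 4 (0.04 log units; within the scatter), no larger than the scatter. Compound 4 is estimated at 70000 nM, with an expected range from 30000 nM to 160000 nM.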

Compound 4, half-maximal inhibitory concentration: 98400 nM
Compound 4: middle estimate off by 1.4-fold (0.15 log units), on the low side; measured number inside the range.
By their numbers in this assay, from the lowest: compounds 1, 3 and 4 (each within the scatter of the next). At a limit, above all of these: compound 2.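

Compound 4 is the first compound shown with a change on this carbon of the five-membered aromatic ring, and in this assay the swap gives a 1.5-fold higher number from compound 1 to compound 4 (0.18 log units; within the scatter). Within this one pair, then, ethynyl, which has no ring, cannot be told apart from thiophen-3-yl, a five-membered aromatic ring, so keeping that ring at this position is not needed for a reading in this range. Nothing shown here explains why the two groups give readings within the scatter of each other.

Still open, on these data alone, is whether any group at this position can move the number beyond the scatter, such as an amine, a carboxylic acid or a longer chain. Also open, as far as these compounds go, is how ethynyl behaves when methyl or methylamino replaces methoxy on the other aromatic carbon.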